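The source may hold more compounds than are shown below. What is called first, only, known or untested is meant among the compounds shown, and "the series" means these compounds.

In an in vitro ADME assay on microsomes from liver (Canis lupus familiaris) for metabolic stability (a lower number here means slower removal, a higher number faster removal of the compound), compound 1 (`Cc1ccc([C@H](C(=O)N(C)C)N2C(=O)[C@@H](C3Cc4ccccc4C3)NC(=O)[C@H]2CC(C)C)cn1`) gives a very high number (3000 mL.min-1.g-1). Compound 2 (`CC[C@H](C)[C@@H]1C(=O)N[C@H](C2Cc3ccccc3C2)C(=O)N1[C@@H](C(=O)N(C)C)c1ccc(C)nc1C`) gives 1 mL.min-1.g-1 and compound 3 (`CC[C@H](C)[C@@H]1C(=O)N[C@H](C2Cc3ccccc3C2)C(=O)N1[C@@H](C(=O)N(C)C)c1cnc(C)cc1C`) gives 1 mL.min-1.g-1, so compound 3 stands level with compound 2 at the lowest number seen so far, far from compound 1.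

Compound 4 (`CC[C@H](C)[C@@H]1C(=O)N[C@H](C2Cc3ccccc3C2)C(=O)N1[C@@H](C(=O)NC)c1cnc(C)cc1C`) alters compound 3 in one place (hydrogen in place of methyl on an amide-type nitrogen): hydrogen in place of methyl on an amide-type nitrogen, which also reads as dimethylcarbamoyl to methylcarbamoyl. For the measured compounds named here, only one measured step changes a single place (no change at the digits printed from compound 2 to compound 3 (within the scatter)). It puts 4,6-dimethylpyridin-3-yl in place of 2,6-dimethylpyridin-3-yl, so it leaves this amide untouched and offers only indirect guidance. Going by the values given here, no measured step shows what this exchange does.

With so little to go on, a step beyond the scatter is not expected, though a slightly higher number would be no surprise. The estimated step is small (a 1.5-fold higher number from compound 3 to compound 4 (0.18 log units; within the scatter)). For compound 4 the expected value is 1.5 mL.min-1.g-1, with an estimated range from 0.5 mL.min-1.g-1 to 6 mL.min-1.g-1.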

Compound 4, intrinsic clearance in microsomes: 4 mL.min-1.g-1
Beside the measured number, compound 4's estimate is 2.7-fold (0.43 log units) below it, and the stated range covers the measured number.
By their numbers in this assay, from the lowest: compounds 2 and 3 (each within the scatter of the next); then compound 4; then compound 1.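

Compound 3 and compound 4 show that the amide on the side chain is a place where a small edit registers in this assay: hydrogen in place of methyl on the amide-type nitrogen gives a 4.0-fold higher number from compound 3 to compound 4 (0.60 log units; beyond the scatter). For the compounds shown here, the other single-place step, with no change at the digits printed from compound 2 to compound 3 (within the scatter), stayed within the scatter, so this is the first such change to move the number beyond it. The compounds offer no measurement that explains the rise.

Still open, as far as these compounds go, is how the number responds to other groups on this nitrogen, such as a longer chain like ethyl, or a primary amide carrying hydrogen in place of both methyls. From the compounds shown here alone, it is also open whether the same exchange on compound 2, with its 2,6-dimethylpyridin-3-yl, would give a step of similar size.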